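Swapping a Cyano Group for a Methoxyphenyl Ring

The compounds below may be only part of what the source reports. "The series", "measured", "known", "first", "only" and "open" are said of these compounds alone.

Compound 1 `CC1CCN(C2CCN(S(=O)(=O)c3ccc(C#N)cc3)CC2)CC1` was tested in an ADME assay on HCT-116 cells (Homo sapiens) for cytotoxicity, read by CellTiter-Glo, with a stated time of 72 h (on this read-out lower numbers stand for stronger inhibition and higher numbers for weaker inhibition), where compound 1 gives only a limit, > 5000 nM. Compound 2 `Cc1nc(Cl)sc1S(=O)(=O)N1CCC(N2CCC(C)CC2)CC1` also gives only a limit in this assay, > 10000 nM. Compound 3 `CC1CCN(C2CCN(S(=O)(=O)c3ccc(Cl)c(Cl)c3)CC2)CC1` likewise gives only a limit in this assay, > 5000 nM. The steps a step that the two limits leave unreadable from compound 1 to compound 2, a step that the two limits leave unreadable from compound 1 to compound 3 and a step that the two limits leave unreadable from compound 2 to compound 3 therefore cannot be sized, since every value sits at the limit of > 10000 nM in this assay, at which 1 of the 3 values shown sits, or (the limit of > 5000 nM in this assay, at which 2 of the 3 values shown sit). Compound 4 `COc1ccc(-c2ccc(S(=O)(=O)N3CCC(N4CCC(C)CC4)CC3)cc2)cc1` differs from compound 1 by 4-methoxyphenyl in place of cyano on an aromatic carbon. Within the data shown here, no measured step bears on this change, and all values so far are limits, so neither a direction nor a size can be drawn from them. Compound 4 is expected to give 6000 nM in this assay, within 1500 nM to 30000 nM, an estimated step that the limit leaves unreadable from compound 1 to compound 4.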

Compound 4, half-maximal inhibitory concentration: > 5000 nM
Compound 4 gave a limit, no number (the forecaster's own chance of this, stated with the estimate: 65%); the middle value does not contradict the limit.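

In this assay compound 4 gives only a limit, > 5000 nM. Among these compounds, compound 1 is also only a limit, so no step from compound 1 to compound 4 can be read. The compounds shown leave open whether any of these swaps shifts the read-out at all.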